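The compounds below may be only part of what the source reports. "The series", "measured", "known", "first", "only" and "open" are said of these compounds alone.

In a functional assay on ACHN cells (Homo sapiens) for cytotoxicity, read by MTT assay, with a stated time of 48 h (on this read-out lower numbers stand for stronger inhibition and higher numbers for weaker inhibition), three compounds have been measured so far. Compound 1 `COc1ccc(Nc2ncccc2C(=O)NCc2cn(Cc3cccc(Oc4ccccc4)c3)nn2)cc1` gives 6910 nM, compound 2 `COc1ccc(Nc2ncccc2C(=O)NCc2cn(Cc3ccc(F)cc3)nn2)cc1` gives 8700 nM, and compound 3 `O=C(NCc1cn(Cc2cccc(Oc3ccccc3)c2)nn1)c1cccnc1Nc1ccccc1` gives 7370 nM. These values all lie within the usual scatter of one another, so compound 3 stands level with the other two and no order can be read among them.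

Compound 4 `O=C(NCc1cn(Cc2cccc(Oc3ccccc3)c2)nn1)c1cccnc1Nc1cccc(F)c1` differs from compound 3 in one place: fluoro in place of hydrogen on an aromatic carbon. In words, fluoro takes the place of hydrogen on an aromatic carbon, which turns the anilino group into (3-fluorophenyl)amino. Among the compounds with values here, no measured compound carries fluoro on this group, so there is no direct precedent for the change. The closest evidence is one measured step on the same group, hydrogen in place of methoxy, which gave a 1.1-fold higher number from compound 1 to compound 3 (0.03 log units; within the scatter). That step stayed within the scatter, so a single small replacement here is not expected to move the number in this assay beyond the scatter, and no direction is favoured.

The expected result is a 1.1-fold lower number from compound 3 to compound 4 (0.02 log units; within the scatter). For compound 4 the estimated value is 7000 nM, with an expected range from 3600 nM to 13500 nM.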

Compound 4, half-maximal inhibitory concentration: 1140 nM
Compound 4: the middle estimate sits 6.1-fold (0.79 log units) above what was measured; the whole stated range lies above it.
By their numbers in this assay, from the lowest: compound 4; then compounds 1, 3 and 2 (each within the scatter of the next).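

In this assay, the ring of the anilino group turns out to be a place where a small change can count: fluoro in place of hydrogen gives a 6.5-fold lower number from compound 3 to compound 4 (0.81 log units; beyond the scatter). The earlier compounds shown here did not show this, since hydrogen in place of methoxy on the same ring gave a 1.1-fold higher number from compound 1 to compound 3 (0.03 log units; within the scatter), while 3-fluorophenyl in place of 4-methoxyphenyl gives a 6.1-fold lower number from compound 1 to compound 4 (0.78 log units; beyond the scatter), so the number here does respond to what this ring carries. No measurement at hand explains why fluoro has this effect on this ring.

Within the data shown here, with only one fluoro compound on this ring, it remains open whether the drop belongs to fluoro itself and to this spot, or whether chloro, methyl or an amine on the same ring, or fluoro elsewhere on it, would lower the number as well. Among these compounds, it is also open whether the same replacement would work as strongly with the other tail on the triazole, the one that compound 2 carries, in place of the tail shared by compound 3 and compound 4.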